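A few compounds are considered here, and "the series" means these few. Any claim that something is new, unique, unknown or untested is made for them only; others in the source may bear on it.

Four close relatives of one amide are compared here in a functional assay on PC-3 cells (Homo sapiens) for cytotoxicity, read by MTT assay, with a stated time of 72 h; on this read-out lower numbers stand for stronger inhibition and higher numbers for weaker inhibition. Compound 1, `COc1ccc(-n2ccc(=O)c(C(=O)Nc3ccc(Oc4ccnc5[nH]ccc45)c(F)c3)n2)cc1`, gives 46400 nM in this assay. Compound 2, `O=C(Nc1ccc(Oc2ccnc3[nH]ccc23)c(F)c1)c1nn(-c2ccc(Br)cc2)ccc1=O`, differs from it by bromo in place of methoxy on an aromatic carbon, and in this assay compound 2 gives 40800 nM; the change amounts to a 1.1-fold lower number from compound 1 to compound 2 (0.06 log units; within the scatter). Compound 3, `COc1ccc(-n2ccc(=O)c(C(=O)Nc3ccc(Oc4ccnc5c4ccn5C)c(F)c3)n2)cc1`, differs from compound 1 by methyl in place of hydrogen on an aromatic nitrogen. For compound 3 this assay reports > 60000 nM, which is a limit of the assay and not a number. The step is therefore an at least 1.2-fold higher number from compound 1 to compound 3 (0.11 log units; that floor lies within the scatter), and it can only be read as reaching (the limit of > 60000 nM in this assay, at which 1 of the 3 values shown sits).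

Compound 4, `Cn1ccc2c(Oc3ccc(NC(=O)c4nn(-c5ccc(Br)cc5)ccc4=O)cc3F)ccnc21`, has not yet been measured. It stands to compound 3 exactly as compound 2 stands to compound 1: the difference is bromo in place of methoxy on an aromatic carbon, and the surroundings of the place are described in the same words for both pairs, so this is the same change made on the core of compound 3 in place of the core of compound 1. Because the earlier instance of this change gave a 1.1-fold lower number from compound 1 to compound 2 (0.06 log units; within the scatter), and because compound 3 already sits at the limit of > 60000 nM in this assay, at which 1 of the 3 values shown sits, the step is expected to be small, about a step that the limit leaves unreadable from compound 3 to compound 4, and most likely to end at the limit again. Compound 4 is therefore estimated at about 70000 nM in this assay. The expected range for compound 4 runs from 35000 nM to 160000 nM.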

Compound 4, half-maximal inhibitory concentration: > 60000 nM
Compound 4 ended at the assay's limit; the forecaster's own chance of this, stated with the estimate: 75%; the middle value lies beyond the limit too.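

Carrying the change from 4-methoxyphenyl to 4-bromophenyl onto the core of compound 3 gives no readable result: in this assay compound 4 gives > 60000 nM, which is a limit of the assay and not a number, and compound 3 also stands at a limit, so the step between them cannot be read. The methyl on the aromatic nitrogen can be followed on both the methoxy and the bromo side, where it gives an at least 1.4-fold higher number from compound 2 to compound 4 (0.16 log units; that floor lies within the scatter), so the data do not show this change acting differently on the two cores, but they do not show it acting alike either: the same change on two cores in this assay, an at least 1.2-fold higher number (0.11 log units; that floor lies within the scatter) from compound 1 to compound 3 and an at least 1.4-fold higher number (0.16 log units; that floor lies within the scatter) from compound 2 to compound 4; the limit leaves it open whether they differ. The two methylated compounds therefore cannot test whether the swap of methoxy for bromo carries over, and the assay's ceiling hides any real size of change in this part of the series: the limit of > 60000 nM in this assay, at which 2 of the 4 values shown sit.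

The compounds shown leave open how the swap of methoxy for bromo behaves on a core that stays clear of the limit, since compound 1 and compound 2 are its only readable pair. They also leave open whether an ethyl or a longer chain ending in an amine on that aromatic nitrogen, or a carboxylic acid in the place of the bromo, would bring the number lower.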